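From piperazin-1-yl to (4-aminocyclohexyl)amino on the shared core

This account rests on a few compounds, and the source may have more. Where it says the series, first, only, none or still open, it means among the compounds named here.

Values in a functional assay on HCT-116 cells (Homo sapiens) for cytotoxicity, read by fluorescence, with a stated time of 72 h (on this read-out lower numbers stand for stronger inhibition and higher numbers for weaker inhibition), for three compounds:
- Compound 1 `CC(C)c1n[nH]c2c(NCc3ccc(-c4ccccn4)cc3)nc(S(C)(=O)=O)nc12` gives 1140 nM
- Compound 2 `CC(C)c1n[nH]c2c(NCc3ccc(-c4ccccn4)cc3)nc(NCC(C)(C)O)nc12` gives 85 nM
- Compound 3 `CC(C)c1n[nH]c2c(NCc3ccc(-c4ccccn4)cc3)nc(N3CCNCC3)nc12` gives 88 nM

Compound 3 lies level with compound 2, within the scatter, and far under compound 1. The next compound is compound 4 `CC(C)c1n[nH]c2c(NCc3ccc(-c4ccccn4)cc3)nc(N[C@H]3CC[C@H](N)CC3)nc12` with (4-aminocyclohexyl)amino in place of piperazin-1-yl on an aromatic carbon between two ring nitrogen atoms, and the change counts as (4-aminocyclohexyl)amino in place of piperazin-1-yl on an aromatic carbon in full.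

Two kinds of measured step bear on this. Replacing methylsulfonyl was a large change, seen as a 13-fold lower number from compound 1 to compound 3 (1.11 log units; beyond the scatter) and as a 13-fold lower number from compound 1 to compound 2 (1.13 log units; beyond the scatter) in the second case, both beyond the scatter. Compound 4 keeps no methylsulfonyl, so the better guide is the swap of one replacement group for the other, which gave a 1.0-fold higher number from compound 2 to compound 3 (0.02 log units; within the scatter) and stayed within the scatter. Among the compounds with values here, that is only one comparison, so little or no change is expected in this assay at this place.

The expected step is a 1.4-fold lower number from compound 3 to compound 4 (0.13 log units; within the scatter) and would probably not exceed the scatter by much. For compound 4 the estimated value is 65 nM with an expected range from 22 nM to 200 nM in this assay.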

Compound 4, half-maximal inhibitory concentration: 720 nM
Compound 4: middle estimate off by 11-fold (1.04 log units), on the low side; the whole stated range lies below it.
By their numbers in this assay, from the lowest: compounds 2 and 3 (each within the scatter of the next); then compounds 4 and 1 (each within the scatter of the next).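

In this assay, within the data shown here, the group at this position matters more than the earlier compounds suggested: (4-aminocyclohexyl)amino gives an 8.2-fold higher number from compound 3 to compound 4 (0.91 log units; beyond the scatter) and an 8.5-fold higher number from compound 2 to compound 4 (0.93 log units; beyond the scatter), both beyond the scatter. Removing methylsulfonyl therefore does not bring stronger inhibition by itself, as the replacement here gives a 1.6-fold lower number from compound 1 to compound 4 (0.20 log units; within the scatter), which is within the scatter and leaves these two compounds level. No measurement here explains why this replacement behaves so differently from the other two.

The compounds shown do not separate the part played by the carbon-only ring from that of its amino group, and a plain cyclohexylamino group would test that directly. From the compounds shown here alone, it also remains open whether the defined stereocentres matter, and whether a 4-hydroxycyclohexylamino group or a 4-methylpiperazin-1-yl group would sit nearer compound 2 and compound 3.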